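This account rests on a few compounds, and the source may have more. Where it says the series, first, only, none or still open, it means among the compounds named here.

Compound 1 `C=C(C)C(=O)NC(=O)NC1=CS(=O)(=O)O[C@@]12[C@@H](CO[Si](C)(C)C(C)(C)C)O[C@@H](n1cc(C)c(=O)n(C)c1=O)[C@@H]2O[Si](C)(C)C(C)(C)C` and compound 2 `CCOC(=O)CNC(=O)NC1=CS(=O)(=O)O[C@@]12[C@@H](CO[Si](C)(C)C(C)(C)C)O[C@@H](n1cc(C)c(=O)n(C)c1=O)[C@@H]2O[Si](C)(C)C(C)(C)C` share a core that differs only at a urea-type nitrogen. In a functional assay on HEL cells (Homo sapiens) for cytotoxicity, read by microscopy (a lower number here means that less compound is tolerated, a higher number that more compound is tolerated), compound 1 gives 20000 nM. In this assay compound 2 gives 16000 nM, and the step of a 1.3-fold lower number from compound 1 to compound 2 (0.10 log units; within the scatter) is within the scatter. Compound 3 `Cc1cn([C@@H]2O[C@H](CO[Si](C)(C)C(C)(C)C)[C@@]3(OS(=O)(=O)C=C3NC(=O)c3ccccc3)[C@H]2O[Si](C)(C)C(C)(C)C)c(=O)n(C)c1=O` carries a benzoyl group on the amine nitrogen in place of the urea-type substituents. In this assay compound 3 gives >= 3200 nM, which is a limit of the assay and not a number, as noted in the limit of >= 3200 nM in this assay, at which 1 of the 3 values shown sits. Because of this limit, the steps a step that the limit leaves unreadable from compound 1 to compound 3 and a step that the limit leaves unreadable from compound 2 to compound 3 cannot be read in size.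

Compound 4 `Cc1cn([C@@H]2O[C@H](CO[Si](C)(C)C(C)(C)C)[C@@]3(OS(=O)(=O)C=C3NCCC(=O)O)[C@H]2O[Si](C)(C)C(C)(C)C)c(=O)n(C)c1=O` differs from compound 3 by 2-carboxyethyl in place of benzoyl on an amine nitrogen. Going by the values given here, no measured step tells what such a change does here, since every step into compound 3 is hidden by its limit. Compounds 1 and 2 show that this core is tolerated at high concentration, so compound 4 is expected to stay in that region, with an estimated step that the limit leaves unreadable from compound 3 to compound 4. The estimate for compound 4 in this assay is 16000 nM, between 4000 nM and 64000 nM.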

Compound 4, minimum cytotoxic concentration: 80000 nM
Compound 4: middle estimate off by 5.0-fold (0.70 log units), on the low side; measured number above the stated range.
By their numbers in this assay, from the lowest: compounds 2 and 1 (each within the scatter of the next); then compound 4.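

At the amine nitrogen, 2-carboxyethyl gives what the two urea-type groups, within the scatter of each other, did not give: a move in this assay beyond the scatter. The change from ((ethoxycarbonyl)methyl)carbamoyl is a 5.0-fold higher number from compound 2 to compound 4 (0.70 log units; beyond the scatter), and the change from ((1-methylethenyl)carbonyl)carbamoyl is a 4.0-fold higher number from compound 1 to compound 4 (0.60 log units; beyond the scatter), so more compound is tolerated with this chain than with either urea-type group. Compound 3 stands at a limit of the assay, so how 2-carboxyethyl compares with benzoyl cannot be read: the limit of >= 3200 nM in this assay, at which 1 of the 4 values shown sits.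

Going by these compounds, it remains open whether the higher number goes with the carboxylic acid or with the chain that carries it. An ethyl ester of the same chain, a longer chain ending in a carboxylic acid, or an amine at the end of the chain could each separate the two.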